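A few compounds are considered here, and "the series" means these few. Any claim that something is new, unique, unknown or untested is made for them only; others in the source may bear on it.

The series shares one macrocyclic core; the compounds differ only in the group on the sulfonyl sulfur. Compound 1 `COc1ccc2c(OCC[C@@H]3NC(=O)N(C)CCCC/C=C\[C@@H]4C[C@@]4(C(=O)NS(=O)(=O)C4(C#N)CC4)NC3=O)cc(-c3nc(C(C)C)cs3)nc2c1Cl` carries a 1-cyanocyclopropyl there. In an ADME assay on cells (Homo sapiens) for activation (on this read-out higher numbers stand for lower toxicity in this test and lower numbers for higher toxicity in this test), compound 1 gives only a limit, > 75000 nM, and no number. Compound 2 `COc1ccc2c(OCC[C@@H]3NC(=O)N(C)CCCCC/C=C\[C@@H]4C[C@@]4(C(=O)NS(=O)(=O)C4CC4)NC3=O)cc(-c3ccccc3)nc2c1` gives 53000 nM in this assay. Compound 3 `COc1ccc2c(OCC[C@@H]3NC(=O)N(C)CCCC/C=C\[C@@H]4C[C@@]4(C(=O)NS(=O)(=O)N4CCC[C@H]4C#N)NC3=O)cc(-c3nc(C(C)C)cs3)nc2c1Cl`, the 2-cyanopyrrolidin-1-yl analogue, gives 28300 nM in this assay. Within the data shown here, the one measured step that alters this position is an at least 2.6-fold lower number from compound 1 to compound 3 (0.42 log units; beyond the scatter); since compound 1 stands at a limit, as the limit of > 75000 nM in this assay, at which 1 of the 3 values shown sits, records, the true size of that step is open.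

Compound 4 `C#CC1(S(=O)(=O)NC(=O)[C@@]23C[C@H]2/C=C\CCCCN(C)C(=O)N[C@@H](CCOc2cc(-c4nc(C(C)C)cs4)nc4c(Cl)c(OC)ccc24)C(=O)N3)CC1` is not yet measured. It differs from compound 1 in one place: ethynyl in place of cyano on a saturated ring carbon. Among the measured compounds shown here, no measured pair covers an exchange of cyano for ethynyl, and the step from compound 1 to compound 3 concerns replacement of the whole ring group, so it bears only loosely on this change. With nothing pointing to a move beyond the scatter, compound 4 is expected to stay close to where compound 1 stands, an estimated step of a number no higher from compound 1 to compound 4 (the limit leaves the size open). The estimate for compound 4 in this assay is 75000 nM, expected between 30000 nM and 150000 nM, with a real chance that only a limit is reported again.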

Compound 4, half-maximal cytotoxic concentration: 26300 nM
Compound 4: middle estimate off by 2.9-fold (0.46 log units), on the high side, and the stated range ends above it.
By their numbers in this assay, from the lowest: compounds 4, 3 and 2 (each within the scatter of the next). At a limit, above all of these: compound 1.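

The earlier step from this position replaced the whole ring group, whereas here the three-membered ring stays and only the group on its saturated ring carbon changes, and that exchange alone gives an at least 2.8-fold lower number from compound 1 to compound 4 (0.45 log units; beyond the scatter). A change confined to cyano and ethynyl is therefore enough to move the read-out in this assay beyond the scatter, and the two analogues of compound 1 cannot be told apart, with a 1.1-fold lower number from compound 3 to compound 4 (0.03 log units; within the scatter), even though they carry quite different groups on the sulfonyl sulfur. Compound 1 remains a limit and not a number, so both steps from it have only a minimum size, and how far the cyano group stands from the other two groups is unknown: the limit of > 75000 nM in this assay, at which 1 of the 4 values shown sits.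

The compounds shown do not settle whether cyano is unusual at this ring carbon, since a methyl, a trifluoromethyl or a carboxamide there, or a bare cyclopropyl on the core of compound 1, would be needed to place it. On these data alone, whether the exchange of cyano for ethynyl gives a step of similar size on other cores also remains open.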